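Replacing an Ethyl Group with Fluorine on a Fused Ring

The source may report more compounds than this note shows. Statements on the series, on what has been measured and on what is new or still open speak of the compounds shown alone.

Of the compounds shown here, three sharing one core have been tested in an assay on isolated protein for inhibition of long-chain fatty acid transport protein 1 (Homo sapiens); a higher number here means a weaker inhibitor, a lower number a stronger inhibitor. Compound 1 `CCn1c(CNc2ccccc2)nnc1SCC(=O)Nc1ccc(C(=O)OC)cc1` gives 540 nM in this assay. Compound 2 `CCn1nnc(-c2ccc(NC(=O)CSc3nnc(CNc4ccccc4)n3CC)cc2)n1` carries 2-ethyl-2H-tetrazol-5-yl in place of methoxycarbonyl on an aromatic carbon. In this assay compound 2 reports > 1000 nM, which is a limit of the assay rather than a number. That exchange amounts to an at least 1.8-fold higher number from compound 1 to compound 2 (0.26 log units; that floor lies within the scatter). Compound 3 `CCc1ccc2oc(CSc3nnc(CNc4ccccc4)n3CC)nc2c1` is the starting point of the step followed here. In this assay compound 3 also reports > 1000 nM, again a limit and not a number. Two of the three values shown thus sit at the limit of > 1000 nM in this assay, at which 2 of the 3 values shown sit, so compound 3 is known only as a weak inhibitor whose exact strength was not resolved.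

Compound 4 `CCn1c(CNc2ccccc2)nnc1SCc1nc2cc(F)ccc2o1` differs from compound 3 by fluoro in place of ethyl on an aromatic carbon. Within the data shown here, the only measured step, from compound 1 to compound 2, alters a different part of the molecule, so no measured step bears on this exchange, and the direction of any change cannot be read from the data. Compound 3 sitting at a limit, compound 4 is expected to stay near that boundary, a step that the limit leaves unreadable from compound 3 to compound 4. In this assay compound 4 is therefore estimated at 1500 nM, with a range from 500 nM to 5000 nM.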

Compound 4, half-maximal inhibitory concentration: > 1000 nM
Compound 4 ended at the assay's limit; the forecaster's own chance of this, stated with the estimate: 60%; the middle value does not contradict the limit.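

Compound 3 and compound 4 both end at a limit of this assay rather than at a number, so the exchange of ethyl for fluoro gives no step that can be read: the limit of > 1000 nM in this assay, at which 3 of the 4 values shown sit.

The compounds shown leave open how strongly compound 3 and compound 4 really inhibit the protein, and whether this exchange changes that strength at all.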